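Adding One Carbon Twice, on Two Related Cores

The compounds below may be only part of what the source reports. "The series", "measured", "known", "first", "only" and "open" are said of these compounds alone.

Compound 1 `CCCN(CC1CC1)C(=O)c1c(C)nc2n1CCCN2c1c(C)cc(C)cc1C` and compound 2 `CCCN(CC1CC1)C(=O)c1c(CC)nc2n1CCCN2c1c(C)cc(C)cc1C` share a core and differ only by methyl in place of hydrogen on a saturated chain carbon bound to an aromatic carbon. In an in vitro assay on IMR-32 cells for displacement of a labelled ligand from corticotropin-releasing factor receptor 1 (Homo sapiens) (a lower number here means a stronger inhibitor, a higher number a weaker inhibitor), compound 1 reaches only > 5000 nM, which is a limit of the assay and not a number. In this assay compound 2 gives 2300 nM. Read together, the two results show an at least 2.1-fold lower number from compound 1 to compound 2 (0.33 log units; beyond the scatter), with the caution that the limit of > 5000 nM in this assay, at which 2 of the 3 values shown sit, leaves the full size of that step open.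

Compound 3 `CCCN(CC1CC1)C(=O)c1c(C)nc2n1CCC(=O)N2c1c(C)cc(C)cc1C` stands on a second core; the difference between the core of compound 3 and that of compound 1 is not broken down here. In this assay compound 3 also reaches only > 5000 nM, again a limit and not a number.

Compound 4 `CCCN(CC1CC1)C(=O)c1c(CC)nc2n1CCC(=O)N2c1c(C)cc(C)cc1C` is the counterpart of compound 2 on the core of compound 3 and carries methyl in place of hydrogen on a saturated chain carbon bound to an aromatic carbon, the same change at the same place. Within the data shown here, the step expected in this assay is a number no higher from compound 3 to compound 4 (the limit leaves the size open), resting on an at least 2.1-fold lower number from compound 1 to compound 2 (0.33 log units; beyond the scatter) as the only measured example of this change. Compound 4 is estimated at 5000 nM, with a likely range from 1500 nM to 20000 nM.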

Compound 4, inhibition constant: > 5000 nM
Compound 4 was reported as a limit; the forecaster's own chance of this, stated with the estimate: 50%; the middle value lies on the limit itself.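

In this assay compound 4 gives > 5000 nM, which is a limit and not a number. Compound 3 also stands at a limit, so no step can be read between the two compounds: the limit of > 5000 nM in this assay, at which 3 of the 4 values shown sit.

The compounds shown leave open whether methyl in place of hydrogen changes the number at all on the core of compound 3.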